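Swapping chloro for cyano on a benzyl ring

The compounds below may be only part of what the source reports. "The series", "measured", "known", "first", "only" and "open" are said of these compounds alone.

Compound 1 `CCOC(=O)c1c(C)nc(-c2cccc(C#N)c2)n1OCCCO`: 11400 nM
Compound 2 `CCOC(=O)c1c(C)nc(-c2cccc(C#N)c2)n1OCc1cccc(Cl)c1`: 19400 nM

Both values come from a functional assay on a cell-free system (plasma, Oryctolagus cuniculus) for inhibition, with stated times of 5 min, 1 min and 6 min; on this read-out lower numbers stand for stronger inhibition and higher numbers for weaker inhibition. Compound 2 has the larger number of the two, but the step of a 1.7-fold higher number from compound 1 to compound 2 (0.23 log units; within the scatter) is within the scatter, so the two cannot be told apart. Compound 3 `CCOC(=O)c1c(C)nc(-c2cccc(C#N)c2)n1OCc1cccc(C#N)c1` differs from compound 2 in one place: cyano in place of chloro on an aromatic carbon. Among the compounds with values here, no measured step swaps chloro for cyano, so nothing bears directly on this change; the one step seen concerns another part of the molecule and was small. The expected step of a 1.1-fold lower number from compound 2 to compound 3 (0.03 log units; within the scatter) is therefore none beyond the scatter. Compound 3 is estimated at 18000 nM, ranging from 7000 nM to 45000 nM.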

Compound 3, half-maximal inhibitory concentration: > 30000 nM
Compound 3: a limit, no number (the forecaster's own chance of this, stated with the estimate: 15%); at least 1.6-fold (0.22 log units) between middle value and limit.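

In this assay compound 3 gives > 30000 nM, which is a limit of the assay and not a number. Cyano in place of chloro gives an at least 1.5-fold higher number from compound 2 to compound 3 (0.18 log units; that floor lies within the scatter), so this change on the benzyl ring has no size that can be read. Within the data shown here, the 3-cyanophenyl in place of 2-hydroxyethyl gives an at least 2.6-fold higher number from compound 1 to compound 3 (0.42 log units; beyond the scatter), the first step at this position that clears the scatter.

On these data alone, the true value of compound 3 stays open. So does whether an amine or a carboxylic acid on this ring would give a lower number.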